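From pyrimidin-2-yl to pyridazin-3-yl on a shared core

The compounds below may be only part of what the source reports. "The series", "measured", "known", "first", "only" and "open" are said of these compounds alone.

In a functional assay on HeLa cells (Homo sapiens) for antiproliferative activity, read by sulforhodamine B assay (on this read-out higher numbers stand for weaker inhibition and lower numbers for stronger inhibition), compound 1 `C/C(=N\Nc1nc2ccccc2o1)c1ncccn1` gives 180 nM. Compound 2 `CCC/C(=N\Nc1nc2ccccc2o1)c1ccccn1` gives 153 nM, and compound 3 `C/C(=N\Nc1nc2ccccc2o1)c1cc2ccccc2cn1` gives 100 nM. All three values lie within the usual scatter of one another, so compound 1 stands level with the other two.

Compound 4 `C/C(=N\Nc1nc2ccccc2o1)c1cccnn1` is still unmeasured. It carries pyridazin-3-yl in place of pyrimidin-2-yl on a carbon with a double bond to nitrogen. The two compounds have the same atoms, joined differently. Among the measured compounds shown here, no measured pair isolates a single change, so the guidance is indirect. No step beyond the scatter is expected, with perhaps a slight drift toward weaker inhibition. The estimated step is a 1.1-fold higher number from compound 1 to compound 4 (0.05 log units; within the scatter). For compound 4, the expected value is 200 nM, within an estimated range of 70 nM to 500 nM.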

Compound 4, half-maximal inhibitory concentration: 1180 nM
Compound 4: the middle estimate sits 5.9-fold (0.77 log units) below what was measured; measured number outside the range, above it.
By their numbers in this assay, from the lowest: compounds 3, 2 and 1 (each within the scatter of the next); then compound 4.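

In this assay, pyridazin-3-yl in place of pyrimidin-2-yl brings a 6.6-fold higher number from compound 1 to compound 4 (0.82 log units; beyond the scatter), meaning weaker inhibition. This place on the shared core therefore responds to how the ring's atoms are joined, even though the heavy-atom and hydrogen-bond acceptor counts stay the same. Nothing available explains why the change has this effect. The compounds shown leave open whether a plain phenyl ring at this place would stay level with compound 1, and whether an amine on the pyridazin-3-yl ring would restore inhibition.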